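The source may hold more compounds than are shown below. What is called first, only, known or untested is meant among the compounds shown, and "the series" means these compounds.

Compound 1 `CN1CCc2nc(C#Cc3cccc(F)c3)sc2C1` — > 10000 nM.
Compound 2 `CC1CC1C(=O)N1CCc2nc(C#Cc3ccccc3)sc2C1` — 9.4 nM.

In an assay on HEK293 cells for positive allosteric modulation of metabotropic glutamate receptor 5 (Homo sapiens), read by FLIPR, with a stated time of 1 h (on this read-out lower numbers stand for an effect already at smaller amounts and higher numbers for an effect only at larger amounts of compound), compound 1 gives > 10000 nM, which is a limit of the assay and not a number, sitting at the limit of > 10000 nM in this assay, at which 1 of the 2 values shown sits. In this assay compound 2 gives 9.4 nM, the only number shown. Compound 3 `O=C(c1cccc(Cl)c1)N1CCc2nc(C#Cc3ccccc3)sc2C1` is not yet measured; it differs from compound 2 by 3-chlorophenyl in place of 2-methylcyclopropyl on a carbonyl carbon. No step between measured compounds is shown, so no measured size guides the change. The step of a 1.3-fold lower number from compound 2 to compound 3 (0.13 log units; within the scatter) is expected to stay within the usual scatter. Compound 3 is estimated in this assay at 7 nM, between 1.5 nM and 35 nM.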

Compound 3, half-maximal effective concentration: 8.7 nM
For compound 3 the middle estimate is 1.2-fold (0.09 log units) below the measured one, within the range that was stated.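

On the carbonyl carbon whose other neighbour is the amide-type nitrogen in a ring, 3-chlorophenyl in place of 2-methylcyclopropyl gives, in this assay, a 1.1-fold lower number from compound 2 to compound 3 (0.03 log units; within the scatter). This place therefore accepts a six-membered aromatic ring of carbon only, with 7 heavy atoms where 4 stood, and the read-out stays within the scatter. Nothing at hand gives a reason for this result.

The compounds shown leave open what an unsubstituted phenyl would give here, which would speak to the part played by the chlorine. They also leave open whether a longer chain or a carboxylic acid would be accepted on this carbonyl carbon.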